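From benzyl to 4-cyanophenyl on the shared core

A few compounds are considered here, and "the series" means these few. Any claim that something is new, unique, unknown or untested is made for them only; others in the source may bear on it.

In a functional assay on T98G cells (Homo sapiens) for inhibition, read by MTT assay, with a stated time of 72 h (a higher number here means a weaker inhibitor, a lower number a stronger inhibitor), compound 3 (`CC1(C)CC(NC(=S)NCc2ccccc2)c2cc(Br)ccc2O1`) gives 54000 nM, and compound 2 (`COc1ccccc1NC(=S)NC1CC(C)(C)Oc2ccc(Br)cc21`) gives 42000 nM, within the scatter of it. Compound 1 (`CC1(C)CC(NC(=S)Nc2ccc(C#N)cc2)c2cc(Cl)ccc2O1`) gives 10000 nM, a number lower than both and beyond the scatter.

Compound 4 (`CC1(C)CC(NC(=S)Nc2ccc(C#N)cc2)c2cc(Br)ccc2O1`) carries 4-cyanophenyl in place of benzyl on an amide-type nitrogen.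

One measured step changes this same nitrogen, a 1.3-fold higher number from compound 2 to compound 3 (0.11 log units; within the scatter), and it stays within the scatter, so benzyl and 2-methoxyphenyl are not separated here. The closer guide is compound 1 at 10000 nM, which already carries 4-cyanophenyl on that nitrogen, although its core holds chlorine where compound 4 holds bromine. Among the measured compounds shown here, no measured pair isolates that halogen exchange, so the guide remains indirect.

A fall to a lower number, beyond the scatter, is therefore expected, with the estimated step being a 4.5-fold lower number from compound 3 to compound 4 (0.65 log units; beyond the scatter). The estimate for compound 4 is 12000 nM, with an expected range of 5000 nM to 30000 nM.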

Compound 4, half-maximal inhibitory concentration: 24000 nM
Estimate against measurement, compound 4: 2.0-fold (0.30 log units) below; low and high end bracket the measured number.
By their numbers in this assay, from the lowest: compound 1; then compounds 4, 2 and 3 (each within the scatter of the next, the first and the last beyond it).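

On the shared core in this assay, 4-cyanophenyl in place of benzyl on the amide-type nitrogen gives a 2.3-fold lower number from compound 3 to compound 4 (0.35 log units; beyond the scatter) and so separates these two groups, if only modestly, whereas a 1.8-fold lower number from compound 2 to compound 4 (0.24 log units; within the scatter) does not separate 4-cyanophenyl from 2-methoxyphenyl. The halogen on the aromatic carbon now has an isolated reading: bromo in place of chloro gives a 2.4-fold higher number from compound 1 to compound 4 (0.38 log units; beyond the scatter) and is also modest, so the value of compound 1 cannot be credited to 4-cyanophenyl alone. Nothing available explains either change in terms of cause.

From the compounds shown here alone, whether the halogen step holds with benzyl or 2-methoxyphenyl on that nitrogen remains open. So does how fluoro on the aromatic carbon, an amine or carboxylic acid on the phenyl ring, or a carbonyl in place of the thiocarbonyl would read.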